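The source may hold more compounds than are shown below. What is called first, only, known or untested is meant among the compounds shown, and "the series" means these compounds.

Three compounds share one core and differ only in the group attached to an aromatic carbon of a five-membered ring with three nitrogen atoms. Compound 1 `O=C1NC(=O)/C(=C/c2ccc(OCCSc3nnc(Cc4ccccc4)[nH]3)cc2)S1` carries a benzyl group there, compound 2 `Cc1ccc(-c2nnc(SCCOc3ccc(/C=C4\SC(=O)NC4=O)cc3)[nH]2)cc1` a 4-methylphenyl group, and compound 3 `O=C1NC(=O)/C(=C/c2ccc(OCCSc3nnc(-c4ccccc4[N+](=O)[O-])[nH]3)cc2)S1` a 2-nitrophenyl group. In a functional assay on the whole organism (strain Wistar) with Rattus norvegicus as the target, with a stated time of 15 days, at a dose of 100 mg/kg by the oral route (a lower number here means a weaker effect, a higher number a stronger effect of the compound at the dose given), compound 1 gives 41.9%, compound 2 gives 54% and compound 3 gives 49.1%. Among the measured compounds shown here, the only step that exceeds the scatter is a number 12.1 percentage points higher from compound 1 to compound 2 (beyond the scatter). Compound 3 sits between the other two without being clearly apart from either: a number 7.2 percentage points higher from compound 1 to compound 3 (within the scatter), and a number 4.9 percentage points lower from compound 2 to compound 3 (within the scatter).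

Compound 4 `O=C1NC(=O)/C(=C/c2ccc(OCCSc3nnc(-c4ccc(Br)cc4)[nH]3)cc2)S1` is the next member. Its change from compound 3 is 4-bromophenyl in place of 2-nitrophenyl on an aromatic carbon. For the measured compounds named here, no measured step swaps these two exact groups, so the expectation rests on neighbouring steps. Placing a ring substituent directly on that aromatic carbon, as in compound 2, gave at most a modest gain over the benzyl of compound 1, and replacing one such ring by another, as from compound 2 to compound 3, stayed within the scatter. The step to compound 4 is therefore expected to be a number 2.9 percentage points higher from compound 3 to compound 4 (within the scatter), not beyond the scatter. Compound 4 is estimated to give 52% in this assay, within a range from 40% to 64%.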

Compound 4, a percentage reported as activity, at one dose (the size of the read-out at that dose, not a potency): 45.7%
Estimate against measurement, compound 4: 6.3 percentage points above; the range from low to high includes it.
By their numbers in this assay, from the lowest: compounds 1, 4, 3 and 2 (each within the scatter of the next, the first and the last beyond it).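

The change takes away the hydrogen-bond acceptors of the 2-nitrophenyl group, which 4-bromophenyl does not have, and in this assay the result is a number 3.4 percentage points lower from compound 3 to compound 4 (within the scatter) on this carbon between two ring nitrogen atoms. Changing only the group on the outer ring of compound 2 gives a number 8.3 percentage points lower from compound 2 to compound 4 (within the scatter) and leaves compound 4 close to the benzyl compound, with a number 3.8 percentage points higher from compound 1 to compound 4 (within the scatter) as the step. A phenyl ring attached directly to this carbon therefore does not by itself bring a step beyond the scatter over benzyl: compound 2 shows such a step, whereas compound 3 and compound 4 do not, and nothing measured here explains that difference.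

As far as these compounds go, every group compared so far at this position has a six-membered carbon ring, so it remains open how an amine or a carboxylic acid on that ring, or a longer chain between the ring and this carbon, would behave. The shared core also stays the same throughout, and these single-dose numbers do not show how potency would compare.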